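The compounds below may be only part of what the source reports. "The series", "measured", "known", "first", "only" and "open" are said of these compounds alone.

Measured in an ADME assay on MT4 cells (Homo sapiens) for cytotoxicity, read by MTT assay, with a stated time of 4 days; a lower number here means that less compound is tolerated, a higher number that more compound is tolerated:
Compound 1 `CCN(C)c1nc(Cc2c(F)cccc2F)cc(=O)[nH]1`: > 89000 nM, a limit.
Compound 2 `CCCN(CCC)c1nc(Cc2c(F)cccc2F)cc(=O)[nH]1`: > 78000 nM, a limit.
Compound 3 `O=c1cc(Cc2c(F)cccc2F)nc(N2CCCCC2)[nH]1`: > 82000 nM, a limit.

Compound 3 therefore has no exact number, and the other two compounds also give only limits, so the three cannot be ranked. The next change leads to compound 4 `CC1CCCN(c2nc(Cc3c(F)cccc3F)cc(=O)[nH]2)C1`: methyl in place of hydrogen on a saturated ring carbon. This is methyl in place of hydrogen on a saturated ring carbon, turning piperidin-1-yl into 3-methylpiperidin-1-yl.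

The closest evidence comes from three exchanges of the amino group on an aromatic carbon: a step that the two limits leave unreadable from compound 1 to compound 3, a step that the two limits leave unreadable from compound 2 to compound 3 and a step that the two limits leave unreadable from compound 1 to compound 2. None of them has a readable size, so they give no direction for the methyl group. No step beyond the scatter is expected in this assay, and compound 4 will probably also be reported only as a limit. The expected outcome is an at least 1.1-fold lower number from compound 3 to compound 4 (0.05 log units; that floor lies within the scatter). Compound 4 is estimated at 72000 nM, with an expected range from 35000 nM to 100000 nM.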

Compound 4, half-maximal cytotoxic concentration: > 78000 nM
Compound 4 was reported as a limit; the forecaster's own chance of this, stated with the estimate: 75%; at least 1.0-fold (0.03 log units) between middle value and limit.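

In this assay compound 4 gives > 78000 nM, which is a limit. Within the data shown here, compound 1, compound 2 and compound 3 also carry only limits, so no step to compound 4 can be read. The compounds shown leave open the actual cytotoxic concentration of all four compounds and whether the methyl group changes it.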